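A few compounds are considered here, and "the series" means these few. Any claim that something is new, unique, unknown or untested is made for them only; others in the source may bear on it.

Working notes on the series. In a functional assay on PC-3 cells (Homo sapiens) for cytotoxicity, read by MTT assay, with a stated time of 72 h (on this read-out lower numbers stand for stronger inhibition and higher numbers for weaker inhibition), compound 2 `COc1ccc(S(=O)(=O)c2nc3ccccc3nc2Nc2cc(OC)c(OC)c(OC)c2)cc1` gives 7850 nM, the highest of the two numbers in hand. Its nearest neighbour is compound 1 `COc1cc(Nc2nc3ccccc3nc2S(=O)(=O)c2ccc(C)cc2)cc(OC)c1OC`, which in this assay gives 4850 nM; the step between them is a 1.6-fold higher number from compound 1 to compound 2 (0.21 log units; within the scatter), and the two values therefore cannot be ordered.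

Compound 3 `COc1cc(Nc2nc3ccccc3nc2S(=O)(=O)c2ccc(F)cc2)cc(OC)c1OC` is not yet measured. It differs from compound 2 in one place: fluoro in place of methoxy on an aromatic carbon. The place is an aromatic carbon of a six-membered aromatic ring of carbon only, para to a large group, the same place at which compound 1 and compound 2 differ. Among the measured compounds shown here, the only measured step that bears on it is a 1.6-fold higher number from compound 1 to compound 2 (0.21 log units; within the scatter), a swap at this place that stayed within the scatter. For the measured compounds named here, no measured step introduces fluoro at this place, so there is no direct precedent for the new group.

On that basis the step from compound 2 to compound 3 in this assay is expected to be a 1.4-fold lower number from compound 2 to compound 3 (0.15 log units; within the scatter), not beyond the scatter. Compound 3 is estimated at 5500 nM in this assay, with a range from 2500 nM to 12000 nM.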

Compound 3, half-maximal inhibitory concentration: > 50000 nM
Compound 3: no number, only a limit; the forecaster's own chance of this, stated with the estimate: 3%; middle value at least 9.0-fold (0.95 log units) away from the limit.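

In this assay compound 3 has no number, only a limit of the assay: the limit of > 50000 nM in this assay, at which 1 of the 3 values shown sits.

This place is not indifferent to the group it carries: the swap of methyl for methoxy stayed within the scatter, whereas fluoro in place of methoxy gives an at least 6.3-fold higher number from compound 2 to compound 3 (0.80 log units; beyond the scatter) and fluoro in place of methyl gives an at least 10-fold higher number from compound 1 to compound 3 (1.01 log units; beyond the scatter). Across these three compounds, the aromatic carbon para to a large group therefore keeps a measurable number in this read-out with methyl or methoxy, but not with fluoro, so the earlier step gave no warning of what this one change could do.

On these data alone, it remains open whether the loss belongs to fluoro alone or extends to other groups that are neither methyl nor methoxy, and a chloro group, an amine or a carboxylic acid at this place would help separate those readings. Compound 3 holds only a limit, so the full size of both steps stays unknown, and these three compounds give no cause for them.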